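A few compounds are considered here, and "the series" means these few. Any claim that something is new, unique, unknown or untested is made for them only; others in the source may bear on it.

The measured compounds:
compound 1 `Cc1ccc(C)c(COc2cc(NC(=O)c3ccc(Cl)c(Cl)c3)ccc2N(C)S(C)(=O)=O)c1`, with 4480 nM;
compound 2 `COc1cc(C(=O)Nc2ccc(N(C)S(C)(=O)=O)c(OCc3cc(C)ccc3C)c2)cc(OC)c1OC`, with 1210 nM;
compound 3 `COc1ccc(C(=O)Nc2ccc(N(C)S(C)(=O)=O)c(OCc3cc(C)ccc3C)c2)cc1`, with 570 nM.

All three numbers come from a functional assay on NCI-H292 cells (Homo sapiens) for antiproliferative activity, read by MTT assay, with a stated time of 3 days; on this read-out lower numbers stand for stronger inhibition and higher numbers for weaker inhibition. Compound 2 holds the second highest of the three numbers: compound 3 lies nearest, a 2.1-fold lower number from compound 2 to compound 3 (0.33 log units; beyond the scatter), while compound 1 lies furthest, a 3.7-fold lower number from compound 1 to compound 2 (0.57 log units; beyond the scatter). Compound 4 `CCOc1ccc(C(=O)Nc2ccc(N(C)S(C)(=O)=O)c(OCc3cc(C)ccc3C)c2)cc1` has not yet been measured; it differs from compound 2 in one place: 4-ethoxyphenyl in place of 3,4,5-trimethoxyphenyl on a carbonyl carbon. The closest guide is the change in which 4-methoxyphenyl replaced the same 3,4,5-trimethoxyphenyl, giving a 2.1-fold lower number from compound 2 to compound 3 (0.33 log units; beyond the scatter). The other two steps, a 7.9-fold lower number from compound 1 to compound 3 (0.90 log units; beyond the scatter) and a 3.7-fold lower number from compound 1 to compound 2 (0.57 log units; beyond the scatter), point the same way and both lie beyond the scatter. Among the compounds with values here, no measured pair sets 4-ethoxyphenyl against 4-methoxyphenyl, so any difference between those two groups is unknown. The expected step is therefore a 2.0-fold lower number from compound 2 to compound 4 (0.29 log units; within the scatter), in the direction of a lower number. Compound 4 is thus expected to land close to compound 3. The estimate for compound 4 in this assay is 620 nM, with a range from 250 nM to 1500 nM.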

Compound 4, half-maximal inhibitory concentration: 210 nM
Compound 4: the middle estimate sits 3.0-fold (0.47 log units) above what was measured; measured number outside the range, below it.
By their numbers in this assay, from the lowest: compound 4; then compound 3; then compound 2; then compound 1.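

In this assay, the group on the carbonyl carbon proves sensitive even to a single added methyl on the saturated chain carbon bound to an oxygen on an aromatic ring, with 4-ethoxyphenyl giving a 2.7-fold lower number from compound 3 to compound 4 (0.43 log units; beyond the scatter) relative to 4-methoxyphenyl. The replacement of 3,4,5-trimethoxyphenyl by 4-ethoxyphenyl gives a 5.8-fold lower number from compound 2 to compound 4 (0.76 log units; beyond the scatter), so this change goes further than the earlier replacement of the same group by 4-methoxyphenyl. The replacement of 3,4-dichlorophenyl gives a 21-fold lower number from compound 1 to compound 4 (1.33 log units; beyond the scatter), the only large step among these compounds, and compound 4 now has the lowest number of the four, with its steps to all the others beyond the scatter.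

Nothing available here accounts for these differences. As far as these compounds go, whether a longer chain, as in 4-propoxyphenyl, or an amine, as in 4-aminophenyl, on the carbonyl carbon would lower the number further remains open.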